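This account rests on a few compounds, and the source may have more. Where it says the series, first, only, none or still open, it means among the compounds named here.

In a functional assay on HCC 2998 cells (Homo sapiens) for inhibition, read by sulforhodamine B assay, with a stated time of 48 h, tested at 10 uM (on this read-out lower numbers stand for a stronger effect and higher numbers for a weaker effect at the one concentration tested), compound 1 `COc1cc2cc(Oc3ccc(NC(=O)Nc4ccccc4)cc3)c(C)nc2cc1OC` gives 105%, compound 2 `COc1cc2cc(Oc3ccc(NC(=O)Nc4cccc(C(F)(F)F)c4)cc3)c(C)nc2cc1OC` gives 25.4%, and compound 3 `COc1cc2cc(Oc3ccc(NC(=O)Nc4ccc(Cl)c(C(F)(F)F)c4)cc3)c(C)nc2cc1OC` gives -13.1%. Compound 3 therefore has the lowest of the three numbers, and both its neighbours lie beyond the scatter from it. Two steps lead to it: a number 118.1 percentage points lower from compound 1 to compound 3 (beyond the scatter), and, from the nearer neighbour, a number 38.5 percentage points lower from compound 2 to compound 3 (beyond the scatter). The other measured step, a number 79.6 percentage points lower from compound 1 to compound 2 (beyond the scatter), shows how much the trifluoromethyl alone accounts for.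

Compound 4 `COc1cc2cc(Oc3ccc(NC(=O)Nc4ccc(Cl)c(Cl)c4)cc3)c(C)nc2cc1OC` is not yet measured. Its change from compound 3 is chloro in place of trifluoromethyl on an aromatic carbon. The chloro that stays is the one whose arrival gave the step from compound 2 to compound 3, so compound 4 keeps that part of what made compound 3 the lowest number. What changes is the trifluoromethyl, whose arrival gave the step from compound 1 to compound 2, being traded for a second chloro. Because a chloro has already produced a large fall in this assay in the step of a number 38.5 percentage points lower from compound 2 to compound 3 (beyond the scatter), the second chloro is expected to hold most of the effect, and the estimated step from compound 3 to compound 4 is a number 13.1 percentage points higher from compound 3 to compound 4 (beyond the scatter), within the scatter. For compound 4 the estimate in this assay is 0%, with a range from -25% to 30%.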

Compound 4, a percentage reported as activity, at one concentration (the size of the read-out at that concentration, not a potency): 37.6%
For compound 4 the middle estimate is 37.6 percentage points below the measured one; the measured number lies above the stated range.
By their numbers in this assay, from the lowest: compound 3; then compound 2; then compound 4; then compound 1.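

At this place on the ring, ortho to a chloro group, trifluoromethyl and chloro are not interchangeable in this assay: with the other chloro held fixed, the swap gives a number 50.7 percentage points higher from compound 3 to compound 4 (beyond the scatter), a large part of the gain seen with compound 3 lost. A trifluoromethyl is still not needed for a large fall, as the 3,4-dichlorophenyl group gives a number 67.4 percentage points lower from compound 1 to compound 4 (beyond the scatter), yet that group stays modestly short of the 3-(trifluoromethyl)phenyl group, with a number 12.2 percentage points higher from compound 2 to compound 4 (beyond the scatter). So among these compounds, the added chloro lowers the number when it joins a trifluoromethyl, but two chloro groups do not match one trifluoromethyl, and no measurement offered here explains the difference.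

The compounds shown leave open where a methyl, a methoxy or a nitrile at this same place would fall relative to trifluoromethyl and chloro, and what a 3-chlorophenyl or 4-chlorophenyl group would give alone. They also leave open whether this order holds at other concentrations or in other cell lines, since all four numbers come from one concentration in one cell line.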